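Swapping a ring end group on a second core

A few compounds are considered here, and "the series" means these few. Any claim that something is new, unique, unknown or untested is made for them only; others in the source may bear on it.

Measured compounds:
compound 1 `CCCCc1nc(=O)c(S(=O)(=O)c2ccc(-c3ccc(F)nc3)cc2)c(O)n1-c1c(OC)cccc1OC`: 69%
compound 2 `CCCCc1nc(=O)c(S(=O)(=O)c2ccc(-n3ccccc3=O)cc2)c(O)n1-c1c(OC)cccc1OC`: 63%

In an ADME assay on microsomes from liver (Mus musculus) for metabolic stability, using NADPH, with a stated time of 10 min (a higher number here means that more of the compound is left, a lower number that less of the compound is left), compound 1 gives 69%, and compound 2 gives 63%. The two differ in one place: a group of 7 heavy atoms (5 carbon, 1 nitrogen, 1 oxygen; one six-membered aromatic ring with 1 hetero atom) in place of a group of 7 heavy atoms (5 carbon, 1 nitrogen, 1 fluorine; one six-membered aromatic ring with 1 hetero atom), on an aromatic carbon. The step this change made is a number 6 percentage points lower from compound 1 to compound 2 (within the scatter), so the two values cannot be told apart by this assay.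

Compound 3 `CCCCc1[nH]c(=O)c(S(=O)(=O)c2ccc(-c3ccc(F)nc3)cc2)c(O)c1-c1c(OC)cccc1OC` carries the same group as compound 1 on a different core; the difference between the two cores is not broken down here. In this assay compound 3 gives "not determined" (no result reported), so no number is known for it.

Compound 4 `CCCCc1[nH]c(=O)c(S(=O)(=O)c2ccc(-n3ccccc3=O)cc2)c(O)c1-c1c(OC)cccc1OC` has not yet been measured. It differs from compound 3 as follows: a group of 7 heavy atoms (5 carbon, 1 nitrogen, 1 oxygen; one six-membered aromatic ring with 1 hetero atom) in place of a group of 7 heavy atoms (5 carbon, 1 nitrogen, 1 fluorine; one six-membered aromatic ring with 1 hetero atom), on an aromatic carbon. Going by the values given here, this is the same change as the one from compound 1 to compound 2, made at the same place on the same kind of ring. Among the compounds with values here, since compound 3 has no value, no step from compound 3 to compound 4 can be computed, and the expectation for compound 4 rests only on what compound 1 and compound 2 show, namely that this change left the value near where it was, with the step of a number 6 percentage points lower from compound 1 to compound 2 (within the scatter). Going by these compounds, how the second core itself behaves is unknown, so the estimate is wide. Compound 4 is expected to give about 60% in this assay, with a range estimated from 30% to 85%.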

Compound 4, percent of the compound remaining: 75%
Beside the measured number, compound 4's estimate is 15 percentage points below it, and the stated range covers the measured number.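

In this assay, going by these compounds alone, compound 4 gives 75% but compound 3 has no number to set against it, so no step from compound 3 to compound 4 can be read. The compounds shown leave open whether replacing the 6-fluoropyridin-3-yl group acts on the core of compound 4 as it does on the core of compound 1. No measured finding shown here accounts for this value.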